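Replacing the 2,2-dicyanoethenyl group with hydroxy

This account rests on a few compounds, and the source may have more. Where it says the series, first, only, none or still open, it means among the compounds named here.

Measured compounds:
compound 1, `CC1(C)C=C(n2ccccc2=O)c2cc(C(=O)c3ccccc3)ccc2O1`, 6.61
compound 2, `CC1(C)C=C(n2ccccc2=O)c2cc(C=C(C#N)C#N)ccc2O1`, 6.95

Of the compounds shown here, two have been measured in a functional assay (aorta) with Rattus norvegicus as the target; a higher number here means a more potent compound, by a factor of ten per unit of this negative logarithm, a lower number a less potent compound. Compound 1 gives 6.61, and compound 2 gives 6.95. For the measured compounds named here, the single step between them, a number 0.34 log units higher from compound 1 to compound 2 (beyond the scatter), exchanges benzoyl for 2,2-dicyanoethenyl on an aromatic carbon of the shared core. Compound 2 therefore holds the higher of the two numbers, and its gap to compound 1 lies beyond the scatter.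

Compound 3, `CC1(C)C=C(n2ccccc2=O)c2cc(O)ccc2O1`, is the next compound. Its difference from compound 2 is hydroxy in place of 2,2-dicyanoethenyl on an aromatic carbon. Going by the values given here, the one measured step concerns a swap between two larger groups at the same place and shifted the read-out modestly; it does not directly cover the loss of the 2,2-dicyanoethenyl group in favour of a single oxygen atom, so the expectation rests on thin ground. The change is estimated to cost potency in this assay, a step of a number 1.35 log units lower from compound 2 to compound 3 (beyond the scatter), with wide uncertainty. Compound 3 is therefore expected to give 5.6, in the range 4.6 to 6.6.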

Compound 3, logarithm of the reciprocal of the active concentration, log(1/C): 5.44
Beside the measured number, compound 3's estimate is 0.16 log units above it; the measured number falls inside the stated range.
By their numbers in this assay, from the lowest: compound 3; then compound 1; then compound 2.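

In this assay, hydroxy on this aromatic carbon gives a number 1.51 log units lower from compound 2 to compound 3 (beyond the scatter), and the same group set against benzoyl gives a number 1.17 log units lower from compound 1 to compound 3 (beyond the scatter). Both steps are large, whereas the exchange between the two bigger groups was only modest, so compound 3, with its single heavy atom at this place, is the least potent of the three and the position is shown to be far from indifferent to what it carries. No measurement here bears on why the number falls.

The three compounds leave open whether the fall goes with the loss of the larger group or with the arrival of the hydroxy itself, since hydroxy alone brings a hydrogen-bond donor to this place and the change alters both at once. A methoxy group, an amine or a short alkyl chain on the same aromatic carbon would help to separate these readings, and a nitrile would show whether part of the 2,2-dicyanoethenyl group is enough to hold the higher number.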